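The source may report more compounds than this note shows. Statements on the series, on what has been measured and on what is new or still open speak of the compounds shown alone.

Of the compounds shown here, three that share one core have been tested in a functional assay on THP-1 cells (Homo sapiens) for antiproliferative activity, tested at 20 uM; a lower number here means a weaker effect, a higher number a stronger effect of the compound at the concentration tested. Compound 1 `CC(=O)Oc1ccc(CONC(=O)c2ccc(CS(=O)(=O)Nc3ccc4cc(C)c(=O)n(C)c4c3)cc2)cc1` gives 1%. Compound 2 `Cc1cc2cc(NS(=O)(=O)c3cc(C(=O)NO)ccc3Cl)ccc2n(C)c1=O` gives 8%. Compound 3 `COc1ccc(C(=O)NOCc2ccccc2)cc1S(=O)(=O)Nc1ccc2c(c1)cc(C)c(=O)n2C` gives 20%, the highest of the three numbers; compound 2 comes nearest, lower by more than the usual scatter, and compound 1 lies further below. Compound 4 `COc1ccc(C(=O)NO)cc1S(=O)(=O)Nc1ccc2c(c1)cc(C)c(=O)n2C` has not yet been measured in this assay. It differs from compound 3 in one place: hydrogen in place of benzyl on an oxygen. Among the compounds with values here, no pair of measured compounds differs in only one place, so the size of such a step has not been seen directly. Compound 2 already carries hydroxycarbamoyl and gives 8%, which points to a number in that region. The step from compound 3 to compound 4 is therefore expected to be a number 8 percentage points lower from compound 3 to compound 4 (within the scatter), a decrease that stays within the scatter. Compound 4 is expected to give 12%, between 0% and 28%.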

Compound 4, a percentage reported as inhibition, at one concentration (the size of the read-out at that concentration, not a potency): 32%
Compound 4: middle estimate off by 20 percentage points, on the low side; measured number outside the range, above it.
By their numbers in this assay, from the lowest: compounds 1 and 2 (each within the scatter of the next); then compound 3; then compound 4.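

Taking the benzyl off the oxygen in this assay gives a number 12 percentage points higher from compound 3 to compound 4 (beyond the scatter) here, so at this position the free hydroxycarbamoyl outperforms (benzyloxy)carbamoyl. Hydroxycarbamoyl alone does not settle the number, since methoxy in place of chloro on an aromatic carbon gives a number 24 percentage points higher from compound 2 to compound 4 (beyond the scatter) with that group present in both compounds. Nothing shown explains either step.

As far as these compounds go, whether a small group such as methyl on that oxygen would keep the number of compound 4 stays open. So does the effect of an amine or a fluorine in place of methoxy.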